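Three Triazole Analogues Measured, a Fourth Still Awaiting Assay

The source may report more compounds than this note shows. Statements on the series, on what has been measured and on what is new or still open speak of the compounds shown alone.

Compound 1 `COc1cc(-n2ncnc2-c2ccc(Cl)cc2)cc(OC)c1OC`, compound 2 `COc1cc(-n2ncnc2-c2ccc(Cl)c(Cl)c2)cc(OC)c1OC` and compound 3 `COc1cc(-c2ncnn2-c2ccc(Cl)cc2)cc(OC)c1OC` were examined in a functional assay on MCF7 cells (Homo sapiens) for antiproliferative activity, read by MTT assay, with a stated time of 72 h; a lower number here means a stronger inhibitor, a higher number a weaker inhibitor. In this assay compound 1 gives > 10000 nM, which is a limit of the assay and not a number. Compound 2 likewise gives only the limit > 10000 nM in this assay. Compound 3 also stops at the limit > 10000 nM in this assay. Compound 1 differs from compound 2 by hydrogen in place of chloro on an aromatic carbon, and the step that the two limits leave unreadable from compound 2 to compound 1 stays unreadable because the limit of > 10000 nM in this assay, at which 3 of the 3 values shown sit, covers both of them.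

Compound 4 `COc1cc(-c2ncnn2-c2ccccc2)cc(OC)c1OC` has not yet been measured. It differs from compound 3 by hydrogen in place of chloro on an aromatic carbon. The difference between the core of compound 3 and the core of compound 2 is not broken down here. Going by the values given here, the change leading to compound 4 is the same kind of change as the one from compound 2 to compound 1, but its place is para to a large group, whereas the earlier one sits ortho to a chloro group and meta to a large group.

For compound 4 a step that the limit leaves unreadable from compound 3 to compound 4 in this assay is expected, which rests on (the limit of > 10000 nM in this assay, at which 3 of the 3 values shown sit). The estimate for compound 4 in this assay is 15000 nM, expected to lie between 7000 nM and 60000 nM, most likely reported again only as a limit.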

Compound 4, half-maximal inhibitory concentration: > 10000 nM
Compound 4: a limit, no number (the forecaster's own chance of this, stated with the estimate: 85%); the middle value is on the limit's open side.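

In this assay compound 4 gives > 10000 nM, which is a limit of the assay and not a number. No size can be read for the change from compound 3 to compound 4 because both compounds stop at the same limit: the limit of > 10000 nM in this assay, at which 4 of the 4 values shown sit.

The compounds shown leave open whether 4-chlorophenyl to phenyl changes activity at all.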